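Branching the Amine Substituent of a Bromoindole Diazepane Series

The source may hold more compounds than are shown below. What is called first, only, known or untested is meant among the compounds shown, and "the series" means these compounds.

Measured so far:
- compound 1, `CN1CCCN(CCn2ccc3ccc(Br)cc32)CC1`: 93%
- compound 2, `Brc1ccc2ccn(CCN3CCCNCC3)c2c1`: 77%
- compound 3, `CC(C)CN1CCCN(CCn2ccc3ccc(Br)cc32)CC1`: 95%

All three were tested in an assay on HEK293 cells for binding affinity to 5-hydroxytryptamine receptor 7 (Homo sapiens), read by radioligand binding, tested at 1 uM; a higher number here means more inhibition at the concentration tested (going by the name of the read-out), a lower number less inhibition. Compound 3 has the highest number of the three, yet its gap to compound 1 lies within the scatter, so the two cannot be told apart; only compound 2 stands clearly lower. The step of a number 18 percentage points higher from compound 2 to compound 3 (beyond the scatter) shows that replacing the ring-amine hydrogen with an isobutyl group raises inhibition, while a number 2 percentage points higher from compound 1 to compound 3 (within the scatter) shows that growing methyl to isobutyl on that nitrogen changes little.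

Compound 4, `CC(C)(C)CN1CCCN(CCn2ccc3ccc(Br)cc32)CC1`, differs from compound 3 by methyl in place of hydrogen on a saturated chain carbon bound to three saturated chain carbons. This lengthens the same side chain one carbon further out, and the most comparable earlier step, a number 2 percentage points higher from compound 1 to compound 3 (within the scatter), stayed within the scatter. With compound 3 already near the top of the scale, compound 4 is therefore expected to show a number 1 percentage points lower from compound 3 to compound 4 (within the scatter). The estimate for compound 4 is 94%, with a range from 85% to 99%.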

Compound 4, a percentage reported as inhibition, at one concentration (the size of the read-out at that concentration, not a potency): 70%
Compound 4: the middle estimate sits 24 percentage points above what was measured; the whole stated range lies above it.
By their numbers in this assay, from the lowest: compounds 4 and 2 (each within the scatter of the next); then compounds 1 and 3 (each within the scatter of the next).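

On the amine nitrogen in the ring, the side chain stays level from methyl to isobutyl but not one step further: methyl in place of hydrogen on a saturated chain carbon bound to three saturated chain carbons gives a number 25 percentage points lower from compound 3 to compound 4 (beyond the scatter) in this assay. The comparison with the methyl compound agrees, with a number 23 percentage points lower from compound 1 to compound 4 (beyond the scatter), while a number 7 percentage points lower from compound 2 to compound 4 (within the scatter) means that the neopentyl compound cannot be told apart from the compound with only hydrogen on that nitrogen, so the gain seen with methyl and isobutyl is gone. No measurement available here explains why one added methyl has this effect.

The compounds shown leave open whether the drop follows the branching at the chain end or the carbon count alone, which a straight n-pentyl chain on the same nitrogen would help to separate. A cyclopentylmethyl group there would show whether a ring at that chain end behaves like the neopentyl group.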